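Aryl group change on the shared core: compound 4

This account rests on a few compounds, and the source may have more. Where it says the series, first, only, none or still open, it means among the compounds named here.

In a functional assay on MV4-11 cells (Homo sapiens) for antiproliferative activity, read by CCK-8 assay, with a stated time of 72 h (a lower number here means a stronger inhibitor, a higher number a weaker inhibitor), compound 1 `Cn1cc(-c2ccccc2F)c2cc(C(=O)NCc3ccc(C(=O)Nc4ccccc4N)cc3)[nH]c2c1=O` gives 230 nM. Compound 2 `Cn1cc(-c2cc(C(C)(C)O)ccc2OC2CC2)c2cc(C(=O)NCCCCCCC(=O)NO)[nH]c2c1=O` gives 220 nM in this assay, and the two values lie within the scatter of each other. Among the compounds with values here, compound 3 `Cn1cc(-c2ccccc2Oc2ccccc2)c2cc(C(=O)NCc3ccc(C(=O)Nc4ccccc4N)cc3)[nH]c2c1=O` gives 80 nM, the lowest of the three, and the step of a 2.9-fold lower number from compound 1 to compound 3 (0.46 log units; beyond the scatter) is the only one beyond the scatter, so compound 1 stands at the high end of the numbers so far. Compound 4 `COc1ccc(-c2cn(C)c(=O)c3[nH]c(C(=O)NCc4ccc(C(=O)Nc5ccccc5N)cc4)cc23)cc1` differs from compound 1 by 4-methoxyphenyl in place of 2-fluorophenyl on an aromatic carbon. Within the data shown here, no measured step swaps a fluoro for a methoxy group; the only step made at the same aromatic carbon, a 2.9-fold lower number from compound 1 to compound 3 (0.46 log units; beyond the scatter), involves a different group and is modest. A modest move in either direction, or none beyond the scatter, is therefore expected, with the estimate for compound 4 at 180 nM, between 70 nM and 450 nM, a step of a 1.3-fold lower number from compound 1 to compound 4 (0.11 log units; within the scatter).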

Compound 4, half-maximal inhibitory concentration: 320 nM
The estimate for compound 4 lay 1.8-fold (0.25 log units) below the measured number; the measured number falls inside the stated range.
By their numbers in this assay, from the lowest: compound 3; then compounds 2, 1 and 4 (each within the scatter of the next).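

In this assay the 2-fluorophenyl and 4-methoxyphenyl groups cannot be told apart at this aromatic carbon (a 1.4-fold higher number from compound 1 to compound 4 (0.14 log units; within the scatter)). Moving to a different substituent at a different ring carbon, with one hydrogen-bond acceptor entering, therefore leaves the number within the scatter, and the phenoxy change (a 2.9-fold lower number from compound 1 to compound 3 (0.46 log units; beyond the scatter)) remains the only step here beyond it. No measurement at hand accounts for either result. Still open, on these data alone, is whether 2-methoxyphenyl or 4-fluorophenyl would separate the substituent from its ring location, and how a 4-aminophenyl group would read.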